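The source may hold more compounds than are shown below. What is called first, only, known or untested is meant among the compounds shown, and "the series" means these compounds.

Measured so far in an assay on mitochondria from L6 cells (Rattus norvegicus) for activation, with a stated time of 90 min; a lower number here means that less compound is needed, a higher number that more compound is needed for the effect:
compound 1 `Oc1nc2nonc2nc1Nc1ccccc1F`: 12500 nM
compound 2 `Oc1nc2nonc2nc1Nc1cccc(S(F)(F)(F)(F)F)c1`: 3700 nM
compound 3 `Oc1nc2nonc2nc1Nc1ccccc1`: 66700 nM

Compound 3 stands highest of the three numbers in this assay. Its nearest neighbour is compound 1, with a 5.3-fold higher number from compound 1 to compound 3 (0.73 log units; beyond the scatter); its furthest is compound 2, with an 18-fold higher number from compound 2 to compound 3 (1.26 log units; beyond the scatter). Both known steps show that a substituent on the aromatic ring is attached to a lower number, and the bulkier substituent to the larger step.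

Compound 4 `Oc1nc2nonc2nc1Nc1ccc(OC(F)(F)Cl)cc1` differs from compound 3 by chloro(difluoro)methoxy in place of hydrogen on an aromatic carbon. The entering group has more heavy atoms than fluoro and fewer than the group of compound 2, so a step downward between the two known ones is expected in this assay, a 7.4-fold lower number from compound 3 to compound 4 (0.87 log units; beyond the scatter). Compound 4 is therefore estimated at 9000 nM, with a range from 2500 nM to 30000 nM.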

Compound 4, half-maximal effective concentration: 1900 nM
Compound 4: the middle estimate sits 4.7-fold (0.68 log units) above what was measured; measured number outside the range, below it.
By their numbers in this assay, from the lowest: compounds 4 and 2 (each within the scatter of the next); then compound 1; then compound 3.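

In this assay, going by these compounds alone, chloro(difluoro)methoxy, para to a large group, gives a 35-fold lower number from compound 3 to compound 4 (1.55 log units; beyond the scatter) and so places compound 4 within the scatter of compound 2, although the group has fewer heavy atoms than the one in compound 2. Heavy-atom count therefore does not order these substituents, and compound 4 goes against the earlier reading. Nothing at hand accounts for this result.

The entering groups of compounds 1, 2 and 4 occupy different places, so the effects of position and group remain inseparable. Going by these compounds, how methoxy or an amine would behave at this position remains open.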